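This account rests on a few compounds, and the source may have more. Where it says the series, first, only, none or still open, it means among the compounds named here.

Of the compounds shown here, three have been tested so far in a functional assay on U-87MG ATCC cells for cytotoxicity against U-87 MG (Homo sapiens), read by colorimetric assay and MTT assay; on this read-out lower numbers stand for stronger inhibition and higher numbers for weaker inhibition. Compound 1 (`COc1ccc(-c2cc3c(OC)ccc(OC)c3nc2O)cc1`) gives 10000 nM, compound 2 (`COc1cc(OC)c2cc(-c3ccc(OCc4ccccc4)cc3)c(O)nc2c1`) gives 10000 nM, and compound 3 (`CCOC(=O)Cn1c(=O)c(-c2ccc(OC)cc2)cc2c(OC)cc(OC)cc21`) gives 10000 nM. Compound 3 therefore stands level with compound 1 and compound 2, with no gap among the three at the digits shown.

The next compound to be tested is compound 4 (`COc1ccc(-c2cc3c(OC)cc(OC)cc3n(CC(=O)OCc3ccccc3)c2=O)cc1`), which differs from compound 3 in one place: phenyl in place of methyl on a saturated chain carbon bound to an oxygen next to a carbonyl group. This turns ethoxycarbonyl into benzyloxycarbonyl. Among the compounds with values here, no two tested compounds differ in only one place, so the data hold no direct measure of a change like this one.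

In this assay no step beyond the scatter is expected, because compound 3 gives 10000 nM and neither other tested compound departs from that value. The expected change is a 1.3-fold lower number from compound 3 to compound 4 (0.10 log units; within the scatter), which is within the scatter. For compound 4 the estimated value is 8000 nM, with an expected range of 3000 nM to 15000 nM.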

Compound 4, half-maximal inhibitory concentration: 10000 nM
Estimate against measurement, compound 4: 1.3-fold (0.10 log units) below; low and high end bracket the measured number.
By their numbers in this assay, from the lowest: compounds 1, 2, 3 and 4 (each within the scatter of the next).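

In this assay, within the data shown here, this is the first direct reading of a change at this position: replacing ethoxycarbonyl with benzyloxycarbonyl gives no change at the digits printed from compound 3 to compound 4 (within the scatter) and nothing more. So placing phenyl in place of methyl on a saturated chain carbon bound to an oxygen next to a carbonyl group, which adds a whole aromatic ring of carbon, leaves the read-out where it was. Nothing measured here gives a reason for this result.

A single step cannot show whether other groups at this place would also leave the number unchanged, such as a free carboxylic acid or an amine in place of ethoxycarbonyl. As far as these compounds go, whether a longer chain would do the same also stays open.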